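The compounds below may be only part of what the source reports. "The series", "measured", "known", "first", "only" and "open" are said of these compounds alone.

Compound 1 `Cc1ccc(C(=O)C(=C2NCCN2)c2c(Cl)c(Cl)c(C#N)c(Cl)c2C#N)cc1` is the starting point of this small series. In a functional assay on HepG2 cells (Homo sapiens) for antiproliferative activity, read by MTT assay (a higher number here means a weaker inhibitor, a lower number a stronger inhibitor), compound 1 gives 15.8 ug/mL. Compound 3 `COc1ccc(C(=O)C(=C2NCCN2)c2c(Cl)c(Cl)c(C#N)c(Cl)c2C#N)cc1` carries the same core and differs from compound 1 in one place: methoxy in place of methyl on an aromatic carbon. In this assay compound 3 gives 10.8 ug/mL, so the step of a 1.5-fold lower number from compound 1 to compound 3 (0.17 log units; within the scatter) is small enough that the two compounds cannot be told apart on this read-out.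

Compound 2 `Cc1ccc(C(=O)C(=C2NCCN2)c2c(Cl)c(F)c(C#N)c(F)c2C#N)cc1` has a different core; the difference between the two cores is not broken down here. In this assay compound 2 gives 49.1 ug/mL, which stands well apart from compound 1 and from compound 3, the inhibition being weaker than in either.

Compound 4 `COc1ccc(C(=O)C(=C2NCCN2)c2c(Cl)c(F)c(C#N)c(F)c2C#N)cc1` has not yet been measured. It stands to compound 2 exactly as compound 3 stands to compound 1: methoxy in place of methyl on an aromatic carbon. The place of the change is the same in both pairs, so this is the same change made on the other core.

For the measured compounds named here, the only guide to what compound 4 may do in this assay is the earlier step, because a 1.5-fold lower number from compound 1 to compound 3 (0.17 log units; within the scatter) was within the scatter and gave no clear direction. On that basis the step of a 1.4-fold lower number from compound 2 to compound 4 (0.15 log units; within the scatter) is expected to be of similar, modest size. Compound 4 is therefore estimated to give about 35 ug/mL in this assay, with a likely range from 15 ug/mL to 80 ug/mL.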

Compound 4, half-maximal inhibitory concentration: 9.8 ug/mL
Compound 4: middle estimate off by 3.6-fold (0.55 log units), on the high side, outside the stated range (below it).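

In this assay, the change from 4-methylphenyl to 4-methoxyphenyl on the core of compound 2 gives a 5.0-fold lower number from compound 2 to compound 4 (0.70 log units; beyond the scatter), a step that lies beyond the scatter, whereas the same change on the core of compound 1 could not be told apart from no change at all. The size of this step therefore did not carry over from one core to the other, as the two steps set side by side show: the same change on two cores in this assay, a 1.5-fold lower number (0.17 log units; within the scatter) from compound 1 to compound 3 and a 5.0-fold lower number (0.70 log units; beyond the scatter) from compound 2 to compound 4, 3.4-fold (0.53 log units) apart, beyond the scatter of two such steps. This does not show why the two cores respond differently, and since the earlier step gave no clear direction, it cannot be said that the change acts in the same direction on both cores; with a single pair on each core, it also gives no rule for any further core.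

The compounds shown leave open whether other groups at the same place, such as ethoxy, hydroxy or a dimethylamino group, would behave like methoxy on either core. They also leave open which of the differences between the two cores governs the gap between the steps, a question that cores differing by a single fluorine or chlorine could address.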